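This account rests on a few compounds, and the source may have more. Where it says the series, first, only, none or still open, it means among the compounds named here.

Measured in a physicochemical assay for permeability, using PAMPA (a higher number here means that the compound crosses the layer faster, a lower number that the compound crosses the layer more slowly), so far:
compound 1 `Cc1oc(-c2ccc(Cl)c(Cl)c2)nc1CN1CCC(C(=O)NCCCN2C[C@H](C)C[C@H](C)C2)CC1` gives 522 10^-6 cm/s;
compound 2 `Cc1oc(-c2c(F)cccc2F)nc1CN1CCC(C(=O)NCCCN2C[C@H](C)C[C@H](C)C2)CC1` gives 82.4 10^-6 cm/s;
compound 3 `COc1cccc(Br)c1-c1nc(CN2CCC(C(=O)NCCCN3C[C@H](C)C[C@H](C)C3)CC2)c(C)o1` gives 245 10^-6 cm/s.

Compound 3 stands second highest of the three numbers. Relative to compound 1 the step is a 2.1-fold lower number from compound 1 to compound 3 (0.33 log units; beyond the scatter), and relative to compound 2 it is a 3.0-fold higher number from compound 2 to compound 3 (0.47 log units; beyond the scatter); the remaining step among the measured compounds is a 6.3-fold lower number from compound 1 to compound 2 (0.80 log units; beyond the scatter). The step to compound 4 `COc1ccc(-c2nc(CN3CCC(C(=O)NCCCN4C[C@H](C)C[C@H](C)C4)CC3)c(C)o2)cc1OC` again exchanges the group on the same aromatic carbon of the shared core: 3,4-dimethoxyphenyl in place of 2-bromo-6-methoxyphenyl on an aromatic carbon. All three measured steps bear on this change, since each of them exchanges the group at that same place, and each was modest in size. Compound 1 with 3,4-dichlorophenyl gave the highest number and compound 2 with 2,6-difluorophenyl the lowest, so exchanges here have shifted this assay by modest amounts in both directions. For the measured compounds named here, no measured compound carries 3,4-dimethoxyphenyl, so the direction rests on judgment; a modest fall beyond the scatter is expected. Compound 4 is therefore expected to give 130 10^-6 cm/s, with a range from 55 10^-6 cm/s to 300 10^-6 cm/s. That estimate corresponds to an expected step of a 1.9-fold lower number from compound 3 to compound 4 (0.28 log units; within the scatter).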

Compound 4, apparent permeability: 81.9 10^-6 cm/s
Compound 4: the middle estimate sits 1.6-fold (0.20 log units) above what was measured, within the range that was stated.
By their numbers in this assay, from the lowest: compounds 4 and 2 (each within the scatter of the next); then compound 3; then compound 1.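

In this assay the exchange of 3,4-dichlorophenyl for 3,4-dimethoxyphenyl gives a 6.4-fold lower number from compound 1 to compound 4 (0.80 log units; beyond the scatter) and so shows that two phenyl groups substituted alike at this place can lie far apart. Set against 2-bromo-6-methoxyphenyl, the same group gives a 3.0-fold lower number from compound 3 to compound 4 (0.48 log units; beyond the scatter) while set against 2,6-difluorophenyl it gives a 1.0-fold lower number from compound 2 to compound 4 (0.00 log units; within the scatter) and so two differently substituted phenyl groups now share the low end of the four numbers. Nothing available explains these differences.

As far as these compounds go, what a plain phenyl, a 3,4-dimethylphenyl or a pyridine ring would give at this place stays open. So does whether a single methoxy group, without the second one of 3,4-dimethoxyphenyl, would stay with compound 4 or move towards compound 1.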